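This account rests on a few compounds, and the source may have more. Where it says the series, first, only, none or still open, it means among the compounds named here.

Three of the four compounds in this set have been tested in an ADME assay on HepG2 cells (Homo sapiens) for cytotoxicity, with a stated time of 3 days; a lower number here means that less compound is tolerated, a higher number that more compound is tolerated. Compound 1 `CC(Sc1nnc(-c2ccncc2)s1)C(=O)Nc1c(Cl)cccc1Cl` carries a 2,6-dichlorophenyl on an amide-type nitrogen whose other neighbour is a carbonyl carbon. In this assay compound 1 gives > 50000 nM, which is a limit of the assay and not a number. Compound 2 `CC(Sc1nnc(-c2ccncc2)s1)C(=O)Nc1ccc(Cl)cc1` carries a 4-chlorophenyl at the same place. In this assay compound 2 gives > 50000 nM, again only a limit. Compound 3 `CC(CSc1nnc(-c2ccncc2)s1)C(=O)Nc1ccc(Cl)cc1` keeps the 4-chlorophenyl of compound 2 but has a different core; how the two cores differ is not broken down here. In this assay compound 3 gives > 50000 nM, also a limit.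

The change from compound 2 to compound 1 is 2,6-dichlorophenyl in place of 4-chlorophenyl on an amide-type nitrogen. The step it produced, a step that the two limits leave unreadable from compound 2 to compound 1, cannot be read, as both ends are limits. All three measured values sit at the same place: the limit of > 50000 nM in this assay, at which 3 of the 3 values shown sit.

Compound 4 `CC(CSc1nnc(-c2ccncc2)s1)C(=O)Nc1c(Cl)cccc1Cl` has not been measured. It differs from compound 3 by 2,6-dichlorophenyl in place of 4-chlorophenyl on an amide-type nitrogen, the same kind of change as that from compound 2 to compound 1, made at the same kind of place. The step expected for compound 4, a step that the limit leaves unreadable from compound 3 to compound 4, is estimated as small because the same change gave a step that the two limits leave unreadable from compound 2 to compound 1 with no readable movement. Compound 4 is therefore expected to give about 80000 nM in this assay, estimated between 30000 nM and 300000 nM, and most probably to be reported again only as a limit.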

Compound 4, half-maximal cytotoxic concentration: > 50000 nM
Compound 4: only a limit was reported; the forecaster's own chance of this, stated with the estimate: 85%; the middle value is on the limit's open side.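

No new step can be read: compound 3 and compound 4 both stand only as limits in this assay, so 2,6-dichlorophenyl in place of 4-chlorophenyl shows no readable size here. The compounds shown leave open where any of them would reach a half-maximal cytotoxic concentration, and whether the two groups or the two cores differ at all, as every result stands at one place: the limit of > 50000 nM in this assay, at which 4 of the 4 values shown sit.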